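A few compounds are considered here, and "the series" means these few. Any claim that something is new, unique, unknown or untested is made for them only; others in the source may bear on it.

Measured compounds
Compound 1, `O=C(NNC(=S)Nc1csc(-c2ccccc2)c1)c1ccc(O)cc1`: 40000 nM
Compound 2, `Cc1ccc(-c2cc(NC(=S)NNC(=O)c3ccc(O)cc3)cs2)cc1`: 48000 nM
Compound 3, `COc1ccc(C(=O)NNC(=S)Nc2csc(-c3ccccc3)c2)cc1OC`: 9000 nM

The three compounds were tested in a functional assay on B16-F10 cells (Mus musculus) for inhibition, read by colorimetric assay and MTT assay, with a stated time of 72 h; a lower number here means a stronger inhibitor, a higher number a weaker inhibitor. Compound 1 and compound 2 share one core and differ by methyl in place of hydrogen on an aromatic carbon; that change gave a 1.2-fold higher number from compound 1 to compound 2 (0.08 log units; within the scatter). Compound 3 carries a different core; how it differs from compound 1 is not broken down here. In this assay compound 3 gives 9000 nM, the lowest of the three numbers, and its gap to each of compound 1 and compound 2 lies beyond the scatter.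

Compound 4, `COc1ccc(C(=O)NNC(=S)Nc2csc(-c3ccc(C)cc3)c2)cc1OC`, has not yet been measured. It stands to compound 3 as compound 2 stands to compound 1: the difference is methyl in place of hydrogen on an aromatic carbon, and since the place is described in the same words for both pairs, it is the same change made on another core.

For the measured compounds named here, the only guide to what this change does is the step from compound 1 to compound 2, which stayed within the scatter. On that basis the step from compound 3 to compound 4 in this assay is expected to be about a 1.1-fold higher number from compound 3 to compound 4 (0.05 log units; within the scatter), that is, small and within the scatter. Compound 4 is therefore estimated at 10000 nM, with a likely range from 5000 nM to 22000 nM, close to the value of compound 3.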

Compound 4, half-maximal inhibitory concentration: 7000 nM
Compound 4: middle estimate off by 1.4-fold (0.15 log units), on the high side; low and high end bracket the measured number.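

In this assay, putting methyl in place of hydrogen on an aromatic carbon, read one bond further out as phenyl to 4-methylphenyl, gave a 1.3-fold lower number from compound 3 to compound 4 (0.11 log units; within the scatter) on the core of compound 3, a step too small to be read as a real change. Set beside the earlier step on the core of compound 1, the change carries over in the sense that it stays small on both cores, and the two steps cannot be told apart: the same change on two cores in this assay, a 1.2-fold higher number (0.08 log units; within the scatter) from compound 1 to compound 2 and a 1.3-fold lower number (0.11 log units; within the scatter) from compound 3 to compound 4, 1.5-fold (0.19 log units) apart, within the scatter of two such steps. This shows only that, on these two cores and in this one cell assay, the methyl leaves the number within the scatter; it does not show that the same would hold on a third core or in another assay, and with just two pairs, both of them small, it says nothing about why the step is small.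

The compounds shown leave open whether a group other than methyl at this place, para to a large group, such as a chlorine atom, a methoxy group, an amine or a carboxylic acid, would move the number beyond the scatter. They also leave open whether a longer chain there, such as ethyl or propyl, would behave as methyl does on either core.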